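The compounds below may be only part of what the source reports. "The series", "measured", "known", "first", "only" and "open" are said of these compounds alone.

Measured compounds:
compound 1 `Cc1c(C)c(S(=O)(=O)N2CCC(N3CCC(C)CC3)CC2)c(C)c2c1OC(C)(C)C2`: > 10000 nM
compound 2 `Cc1ccc(C2CCN(S(=O)(=O)c3c(C)cc(C)cc3C)CC2)cc1`: > 5000 nM

In an ADME assay on HCT-116 cells (Homo sapiens) for cytotoxicity, read by CellTiter-Glo, with a stated time of 72 h (on this read-out lower numbers stand for stronger inhibition and higher numbers for weaker inhibition), compound 1 gives only a limit, > 10000 nM (the limit of > 10000 nM in this assay, at which 1 of the 2 values shown sits). Compound 2 likewise gives only a limit in this assay, > 5000 nM (the limit of > 5000 nM in this assay, at which 1 of the 2 values shown sits). Among the compounds with values here, compound 2 therefore stands at a limit, and the one other value shown in this assay is a limit as well; no number is fixed for either. Compound 3 `Cc1cc(C)c(S(=O)(=O)N2CCC(N3CCC(O)CC3)CC2)c(C)c1` is not yet measured in this assay.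

4-hydroxypiperidin-1-yl in place of 4-methylphenyl on a saturated ring carbon

Within the data shown here, no measured step between two compounds differing in one place is available, and the only comparison, compound 1 against compound 2, shows two limits. The expected step is a step that the limit leaves unreadable from compound 2 to compound 3, none beyond the scatter in this assay. For compound 3 the estimate in this assay is 15000 nM, within 5000 nM to 50000 nM, most likely reported again as a limit.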

Compound 3, half-maximal inhibitory concentration: > 5000 nM
Compound 3: a limit, no number (the forecaster's own chance of this, stated with the estimate: 80%); the middle value does not contradict the limit.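

Compound 2 and compound 3 both give only a limit in this assay, and no step between them can be read: the limit of > 5000 nM in this assay, at which 2 of the 3 values shown sit.

Left open is whether 4-hydroxypiperidin-1-yl in place of 4-methylphenyl on a saturated ring carbon changes the read-out at all, and at what concentration any compound shown reaches half-maximal inhibition.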